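The compounds below may be only part of what the source reports. "The series", "measured", "known", "first", "only" and "open" are said of these compounds alone.

Measured compounds and their values in a functional assay on K562 cells (Homo sapiens) for cytotoxicity, read by MTT assay; a higher number here means that more compound is tolerated, a lower number that less compound is tolerated:

Compound 1 `COC1C=C(CCC/C(C)=C\CC/C(C)=C\CC[C@@H](C)/C=C2\OC(=O)C(C)=C2O)C(OC)O1`: 83 ug/mL
Compound 2 `CC1=C(O)/C(=C/[C@H](C)CC/C=C(/C)CC/C=C(/C)CCCc2ccoc2)OC1=O`: 62 ug/mL
Compound 3 `CC1=C(O)/C(=C/[C@H](C)CCC/C(C)=C/CC/C(C)=C/CCc2ccoc2)OC1=O`: 39 ug/mL

Compound 1 and compound 2 differ in one place, namely (a group of 9 heavy atoms (6 carbon, 3 oxygen; one five-membered non-aromatic ring with 1 hetero atom) in place of a group of 5 heavy atoms (4 carbon, 1 oxygen; one five-membered aromatic ring with 1 hetero atom), on a saturated chain carbon, three bonds along the chain from a double-bonded chain carbon). This exchange gives a 1.3-fold higher number from compound 2 to compound 1 (0.13 log units; within the scatter), so the two compounds are not separated in this assay. Compound 3 is built from the same atoms as compound 2, joined differently; the difference between the two cores is not broken down here. Compound 3 stands at the lowest number of the three, though its gap to compound 2 lies within the scatter, while its gap to compound 1 lies beyond it.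

Compound 4 `COC1C=C(CC/C=C(\C)CC/C=C(\C)CCC[C@@H](C)/C=C2\OC(=O)C(C)=C2O)C(OC)O1` is the untested member of the set. It differs from compound 3 by a group of 9 heavy atoms (6 carbon, 3 oxygen; one five-membered non-aromatic ring with 1 hetero atom) in place of a group of 5 heavy atoms (4 carbon, 1 oxygen; one five-membered aromatic ring with 1 hetero atom), on a saturated chain carbon, two bonds along the chain from a double-bonded chain carbon. For the measured compounds named here, this is the same kind of change as the one from compound 2 to compound 1, but not the same: there the group sits three bonds along the chain from a double-bonded chain carbon, here two bonds along the chain from a double-bonded chain carbon. Since the same kind of exchange on the core of compound 2 gave a 1.3-fold higher number from compound 2 to compound 1 (0.13 log units; within the scatter), a step of similar size, a 1.3-fold higher number from compound 3 to compound 4 (0.11 log units; within the scatter), is expected here. On that basis, with compound 3 at 39 ug/mL as the anchor, compound 4 is estimated at 50 ug/mL, with a range of 30 ug/mL to 85 ug/mL expected.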

Compound 4, concentration lethal to 50% of the cells: 80 ug/mL
Compound 4: middle estimate off by 1.6-fold (0.20 log units), on the low side, within the range that was stated.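

In this assay, the exchange of the furan-3-yl group for the larger non-aromatic five-membered ring group, on a saturated chain carbon two bonds along the chain from a double-bonded chain carbon, gives a 2.1-fold higher number from compound 3 to compound 4 (0.31 log units; beyond the scatter), a modest step that on its own lies beyond the scatter. Set beside the earlier exchange, where the group sits three bonds along the chain from a double-bonded chain carbon, this step cannot be told apart from it: the same change on two cores in this assay, a 1.3-fold higher number (0.13 log units; within the scatter) from compound 2 to compound 1 and a 2.1-fold higher number (0.31 log units; beyond the scatter) from compound 3 to compound 4, 1.5-fold (0.19 log units) apart, within the scatter of two such steps So, on these two pairs, the exchange carries from one core to the other in this assay without a measurable difference in size, but this does not show that the two steps are equal, that the step is independent of the core, or that only one of them can be read as a real shift, as a single step lies beyond the scatter and the other within it.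

On these data alone, it remains open whether the exchange would keep this size on a core with a longer chain. As far as these compounds go, how a carboxylic acid or an amine would read in this assay in place of the furan-3-yl group also remains open.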